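Series notes: exchanging the amine substituent on the shared core

A few compounds are considered here, and "the series" means these few. Any claim that something is new, unique, unknown or untested is made for them only; others in the source may bear on it.

Two compounds of the series have been examined in a functional assay on cells (T-cell, Homo sapiens) for inhibition; a higher number here means a weaker inhibitor, a lower number a stronger inhibitor. Compound 1 `CC(C)Oc1nc(N)nc2ncc(-c3ccc(C#N)cc3)nc12` returns only a limit in that setting, > 10000 nM, and not a number. Compound 2 `COc1ccc(-c2cnc3nc(N)nc(NCc4ccccc4)c3n2)cc1OC` gives 13000 nM in this assay. Compound 2 therefore holds the only number shown; the other entry is the limit recorded for compound 1, as stated by the limit of > 10000 nM in this assay, at which 1 of the 2 values shown sits, so there is nothing to rank compound 2 against and no measured step between compounds that differ in a single place.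

Compound 3 `COc1ccc(-c2cnc3nc(N)nc(N4CCC(C)CC4)c3n2)cc1OC` is the next compound to be tested and differs from compound 2 in one place: 4-methylpiperidin-1-yl in place of benzylamino on an aromatic carbon. Among the measured compounds shown here, no measured pair in the set shows what such an exchange does, so any expectation rests on the value of compound 2 alone and on the size of the change. In this assay the outcome for compound 3 is estimated at 15000 nM, with a range from 4000 nM to 60000 nM. That estimate means an expected step of a 1.2-fold higher number from compound 2 to compound 3 (0.06 log units; within the scatter), lying within the usual scatter, with no direction claimed beyond it.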

Compound 3, half-maximal inhibitory concentration: 800 nM
For compound 3 the middle estimate is 19-fold (1.27 log units) above the measured one, and the stated range ends above it.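

In this assay, among the compounds shown here, the position on an aromatic carbon next to the ring nitrogen gives the first single-place comparison, and the number there is clearly sensitive to the group it carries: 4-methylpiperidin-1-yl in place of benzylamino gives a 16-fold lower number from compound 2 to compound 3 (1.21 log units; beyond the scatter). The exchange alters several features at once, since the hydrogen-bond donor of benzylamino and its aromatic ring of carbon only leave together, and a non-aromatic ring with no donor enters, so this one step cannot assign the change to any single feature. Nothing among the data available gives a cause for the step.

Going by these compounds, it remains open whether the 4-methyl group contributes to the change, or whether the ring alone suffices; the unsubstituted piperidin-1-yl and morpholin-4-yl would be the direct tests of that. For the compounds shown here, it is also open whether the same exchange has a step of similar size when the other substituents on the shared core differ, as no second pair shows this change.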